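A Changed Aromatic Ring on the Ether Oxygen

The source may report more compounds than this note shows. Statements on the series, on what has been measured and on what is new or still open speak of the compounds shown alone.

Compound 1 `COc1ccccc1Oc1ccc2c(NCCCNCc3ccco3)ccnc2c1` gives 6500 nM
Compound 2 `COc1ccc(F)cc1CNCCCNc1ccnc2cc(Cc3cc(C)cc(C)c3)ccc12` gives 940 nM
Compound 3 `COc1cccc(CNCCCNc2ccnc3cc(Oc4ccc(Cl)cc4)ccc23)c1O` gives 5700 nM

All three numbers come from an ADME assay on HepG2 cells (Homo sapiens) for cytotoxicity, read by luminescence, CellTiter-Glo and ATP content, with a stated time of 72 h; a lower number here means that less compound is needed, a higher number that more compound is needed for the effect. Among them, compound 3 stands second highest. Its nearest neighbour is compound 1, whose number lies within the usual scatter of the value of compound 3, so the two cannot be told apart. Compound 2 is the furthest away: its number is lower, beyond the scatter, meaning less of compound 2 is needed to reach the same effect on the cells.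

Compound 4 `COc1cccc(Oc2ccc3c(NCCCNCc4cccc(OC)c4O)ccnc3c2)c1` has not yet been measured. It differs from compound 3 in one place: 3-methoxyphenyl in place of 4-chlorophenyl on an oxygen on an aromatic ring. For the measured compounds named here, no two measured compounds differ in a single place, so there is no measured step to lean on. What can be said is that compound 1, which also carries an aromatic ring on an oxygen on the shared core, gives 6500 nM, close to compound 3 with 5700 nM.

From compound 3 to compound 4 the expected step in this assay is a 1.1-fold higher number from compound 3 to compound 4 (0.06 log units; within the scatter), that is, no change beyond the scatter. Compound 4 is therefore estimated at 6500 nM, with a likely range from 2500 nM to 17000 nM.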

Compound 4, half-maximal effective concentration: 5300 nM
Estimate against measurement, compound 4: 1.2-fold (0.09 log units) above; low and high end bracket the measured number.
By their numbers in this assay, from the lowest: compound 2; then compounds 4, 3 and 1 (each within the scatter of the next).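

For the compounds shown here, for the first time, a single change can be read directly: in this assay, 3-methoxyphenyl in place of 4-chlorophenyl on an oxygen on an aromatic ring gives a 1.1-fold lower number from compound 3 to compound 4 (0.03 log units; within the scatter). Within this one pair, the read-out therefore does not separate the two groups, although one carries a chlorine and the other a methoxy group, which adds a hydrogen-bond acceptor, while a six-membered aromatic ring of carbon stays in place on the oxygen. Nothing in the available data explains why this exchange leaves the number within the scatter.

On these data alone, one pair describes only these two aromatic groups, so it remains open how this assay would respond if a non-aromatic group, such as a simple amine, a carboxylic acid or a longer carbon chain, stood on that oxygen. As far as these compounds go, it also remains open whether the same exchange would again stay within the scatter in a compound with a longer chain joining the two nitrogens of the side chain.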